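The compounds below may be only part of what the source reports. "The series", "measured", "known", "first", "only" and "open" are said of these compounds alone.

Measured compounds:
- compound 1, `CN1C(=O)C2(C(C#N)=C(N)Oc3cc4oc(-c5ccccc5)cc(=O)c4c(O)c32)c2cccc(Cl)c21`, 41400 nM
- compound 2, `N#CC1=C(N)Oc2cc3oc(-c4ccccc4)cc(=O)c3c(O)c2C12C(=O)N(Cc1ccccc1)c1c(Cl)cccc12`, 47800 nM
- compound 3, `N#CC1=C(N)Oc2cc3oc(-c4ccccc4)cc(=O)c3c(O)c2C12C(=O)Nc1ccccc12`, 36400 nM

All three compounds were tested in a functional assay on K562 cells (Homo sapiens) for antiproliferative activity, read by MTT assay, with a stated time of 48 h; a lower number here means a stronger inhibitor, a higher number a weaker inhibitor. Compound 3 gives the lowest of the three numbers, but its gaps to compound 1 and to compound 2 both lie within the usual scatter, so the three cannot be told apart on these data. Among the measured compounds shown here, the only step between two compounds that differ in a single place, from compound 1 to compound 2, is a 1.2-fold higher number from compound 1 to compound 2 (0.06 log units; within the scatter); it concerns a phenyl on a saturated chain carbon bound to an amide-type nitrogen, not the aromatic ring.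

Compound 4, `N#CC1=C(N)Oc2cc3oc(-c4ccccc4)cc(=O)c3c(O)c2C12C(=O)Nc1c(Cl)cccc12`, differs from compound 3 by chloro in place of hydrogen on an aromatic carbon. Compound 1 and compound 2 each carry that chloro on the same ring, and their values sit within the scatter of compound 3, though neither forms a single-change pair with compound 3. For the measured compounds named here, no step directly bears on this change, and the one step available was flat. For compound 4, the expected step of a 1.1-fold higher number from compound 3 to compound 4 (0.04 log units; within the scatter) is therefore none beyond the scatter, and compound 4 is estimated at 40000 nM, within 18000 nM to 90000 nM.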

Compound 4, half-maximal inhibitory concentration: 37500 nM
Compound 4: middle estimate off by 1.1-fold (0.03 log units), on the high side; the measured number falls inside the stated range.
By their numbers in this assay, from the lowest: compounds 3, 4, 1 and 2 (each within the scatter of the next).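

In this assay, the chloro on this aromatic carbon can now be judged on its own, and the step is a 1.0-fold higher number from compound 3 to compound 4 (0.01 log units; within the scatter), so compounds with and without it cannot be told apart. The new compound also isolates the group on the amide-type nitrogen: hydrogen in place of methyl gives a 1.1-fold lower number from compound 1 to compound 4 (0.04 log units; within the scatter), and hydrogen in place of benzyl gives a 1.3-fold lower number from compound 2 to compound 4 (0.11 log units; within the scatter), so neither group can be told apart from hydrogen there. No independent measurement accompanies these results to explain them.

Going by these compounds, whether an amine or a carboxylic acid on this aromatic carbon would give a step beyond the scatter remains open. The same is true of a longer chain on the amide-type nitrogen, or of replacing the phenyl on the shared core.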